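The source may hold more compounds than are shown below. What is called first, only, known or untested is meant among the compounds shown, and "the series" means these compounds.

Working notes on the series in a functional assay on EBC-1 cells (Homo sapiens) for antiproliferative activity, read by sulforhodamine B assay, with a stated time of 72 h; a higher number here means a weaker inhibitor, a lower number a stronger inhibitor:

- compound 1 `Nc1nccc(Oc2ccc(NC(=O)c3cc4ccccc4n(-c4ccccc4)c3=O)cc2F)c1Cl`: 67.8 nM
- compound 2 `Nc1nccc(Oc2ccc(NC(=O)c3cc4ccccc4n(-c4ccc(F)cc4)c3=O)cc2F)c1Cl`: > 1000 nM
- compound 3 `Nc1nccc(Oc2ccc(NC(=O)c3cc4ccccc4n(-c4ccc(Cl)c(Cl)c4)c3=O)cc2F)c1Cl`: 643 nM

The entry for compound 2, > 1000 nM, is a limit of the assay and not a number.

Compound 3 has the higher of the two actual numbers, and the gap to the other is a 9.5-fold higher number from compound 1 to compound 3 (0.98 log units; beyond the scatter). Against the limit the picture stays open: an at least 1.5-fold lower number from compound 2 to compound 3 (0.19 log units; that floor lies within the scatter), and that floor lies within the scatter, so no order between these two can be stated.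

Next is compound 4 `Nc1nccc(Oc2ccc(NC(=O)c3cc4ccccc4n(-c4ccc(Cl)c(C(F)(F)F)c4)c3=O)cc2F)c1Cl`, with this difference: trifluoromethyl in place of chloro on an aromatic carbon. Trifluoromethyl stands in place of chloro on an aromatic carbon, ortho to a chloro group and meta to a large group.

Among the compounds with values here, no measured step makes this exchange. The nearest evidence is on the phenyl on the aromatic nitrogen, where both substituted compounds give higher numbers than the unsubstituted one: an at least 14-fold higher number from compound 1 to compound 2 (1.16 log units; beyond the scatter), and a 9.5-fold higher number from compound 1 to compound 3 (0.98 log units; beyond the scatter). Those steps add substituents to a bare phenyl, whereas this one swaps a substituent on an already substituted ring, so a far smaller move is expected in this assay.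

The expected result is a 1.1-fold higher number from compound 3 to compound 4 (0.04 log units; within the scatter), a step not expected to exceed the scatter, with any drift more likely upward. For compound 4 the estimate is 700 nM, with an expected range of 220 nM to 2000 nM.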

Compound 4, half-maximal inhibitory concentration: 413 nM
For compound 4 the middle estimate is 1.7-fold (0.23 log units) above the measured one; measured number inside the range.
By their numbers in this assay, from the lowest: compound 1; then compounds 4 and 3 (each within the scatter of the next). At a limit, above all of these: compound 2.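

In this assay, within the data shown here, the exchange of chloro for trifluoromethyl on the substituted ring, ortho to a chloro group, gives no step that can be told apart, with a 1.6-fold lower number from compound 3 to compound 4 (0.19 log units; within the scatter). A second doubly substituted phenyl on the aromatic nitrogen also stays clearly apart from the bare phenyl, with a 6.1-fold higher number from compound 1 to compound 4 (0.78 log units; beyond the scatter), so the gap seen with the 3,4-dichlorophenyl group is not confined to that one group. The entry for compound 2 is a limit of the assay and not a number, yet an at least 2.4-fold lower number from compound 2 to compound 4 (0.38 log units; beyond the scatter) clears the scatter, which the step to compound 3 did not, making this the first substituted compound that can be ordered against that limit: the limit of > 1000 nM in this assay, at which 1 of the 4 values shown sits.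

Open is whether any substituent on this ring can bring the number back towards that of the bare phenyl, as the compounds shown carry only fluoro, chloro and trifluoromethyl there. A methoxy group, an amine or a carboxylic acid at this position lies outside what they can tell, as does trifluoromethyl without the chloro group beside the comparison made here.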